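Removing the undecyl chain from a cytotoxicity lead

A few compounds are considered here, and "the series" means these few. Any claim that something is new, unique, unknown or untested is made for them only; others in the source may bear on it.

Compound 1 `CCCCCCCCCCCO[C@@H]1[C@@H](O)[C@H](O[C@H]2O[C@H](CN)[C@@H](O)[C@H](OCCCCCCC)[C@H]2N)[C@@H](N)C[C@H]1N` was tested in an ADME assay on J774 cells (Mus musculus) for cytotoxicity, read by MTT assay, with a stated time of 24 h, tested at 10 uM (a higher number here means a weaker effect of the compound at the concentration tested, a lower number a stronger effect), where compound 1 gives 82.9%. Among the three compounds measured it carries the lowest number, yet the other two sit within the scatter: compound 3 `CCCCCCCCCCO[C@@H]1[C@@H](N)[C@@H](O[C@H]2[C@H](O)[C@@H](OCCCCCCCCCC)[C@H](N)C[C@@H]2N)O[C@H](CN)[C@H]1O` gives 85.5% and compound 2 `CCCCCCCCCCCO[C@@H]1[C@@H](N)[C@@H](O[C@H]2[C@H](O)[C@@H](OCCCCCCC)[C@H](N)C[C@@H]2N)O[C@H](CN)[C@H]1O` gives 88.4%, so no real difference between the three can be claimed.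

Compound 4 `CCCCCCCO[C@@H]1[C@@H](N)[C@@H](O[C@H]2[C@H](O)[C@@H](O)[C@H](N)C[C@@H]2N)O[C@H](CN)[C@H]1O` has not yet been measured. It differs from compound 1 in one place: hydrogen in place of undecyl on an oxygen on a saturated carbon. Within the data shown here, no measured pair shows what such a change does here, so the expectation rests on compound 1 alone. Because compound 1 already gives 82.9%, the step of a number 9.1 percentage points higher from compound 1 to compound 4 (within the scatter) is expected to be small, upward if anything, and probably not beyond the scatter. Compound 4 is estimated at 92%, in a range from 80% to 100%.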

Compound 4, a percentage reported as activity, at one concentration (the size of the read-out at that concentration, not a potency): 77.5%
Beside the measured number, compound 4's estimate is 14.5 percentage points above it, outside the stated range (below it).
By their numbers in this assay, from the lowest: compounds 4, 1, 3 and 2 (each within the scatter of the next, the first and the last beyond it).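

Hydrogen in place of undecyl on this oxygen gives a number 5.4 percentage points lower from compound 1 to compound 4 (within the scatter) in this assay, the first direct reading of this change. Among these compounds, the whole undecyl chain can therefore leave this place with no effect that stands clear of the usual scatter, something the earlier compounds, which differ from each other in more than one place, could not show. Nothing shown here explains this step.

As far as these compounds go, whether a methyl group, a hexadecyl chain or an aminoethyl group on this oxygen would also stay within the scatter remains open.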